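A Further Chloro on a Weak Inhibitor

The source may hold more compounds than are shown below. What is called first, only, known or untested is meant among the compounds shown, and "the series" means these compounds.

Compound 1 `Nc1nc2cc(Cl)c(Cl)cc2n1Cc1ccc(Cl)c(Cl)c1`: 35000 nM
Compound 2 `Clc1ccc(Cn2c(Cl)nc3cc(Cl)c(Cl)cc32)cc1`: > 100000 nM

In a functional assay on KB cells (Homo sapiens) for inhibition (a lower number here means a stronger inhibitor, a higher number a weaker inhibitor), compound 2 gives > 100000 nM, which is a limit of the assay and not a number. Compound 3 `Clc1ccc(Cn2c(Cl)nc3cc(Cl)c(Cl)cc32)cc1Cl` has chloro in place of hydrogen on an aromatic carbon of compound 2 (chloro in place of hydrogen on an aromatic carbon). For the measured compounds named here, no measured step shows what this change does. Compound 1 at 35000 nM is itself a weak inhibitor, so compound 3 is expected to stay weak. The expected change is small and towards stronger inhibition in this assay: an at least 1.4-fold lower number from compound 2 to compound 3 (0.15 log units; that floor lies within the scatter). For compound 3 the estimate is 70000 nM, with an expected range of 25000 nM to 100000 nM.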

Compound 3, half-maximal inhibitory concentration: > 100000 nM
Compound 3: only a limit was reported (the forecaster's own chance of this, stated with the estimate: 55%); at least 1.4-fold (0.15 log units) between middle value and limit.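

In this assay, a chloro added ortho to a chloro group gives a step that cannot be read, because compound 2 and compound 3 both sit at the limit of the assay: the limit of > 100000 nM in this assay, at which 2 of the 3 values shown sit.

The amino group is what the new result speaks to: chloro in place of amino on an aromatic carbon gives an at least 2.8-fold higher number from compound 1 to compound 3 (0.45 log units; beyond the scatter). The amino compound is therefore the only one of the three with a measured number.

From the compounds shown here alone, whether the added chloro has any effect stays open. So does how a longer amine chain or a carboxylic acid in place of that amino group would read.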